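This account rests on a few compounds, and the source may have more. Where it says the series, first, only, none or still open, it means among the compounds named here.

Measured compounds in a functional assay on CCRF-CEM cells (Homo sapiens) for antiproliferative activity, read by MTT assay, with a stated time of 48 h, tested at 25 uM; on this read-out lower numbers stand for a stronger effect and higher numbers for a weaker effect at the one concentration tested:
- compound 1, `OC(CCn1nc2c(Br)c(Br)c(Br)c(Br)c2n1)c1cccc(Br)c1` — compound 1 gives 54%
- compound 2, `OC(CCn1nc2c(Br)c(Br)c(Br)c(Br)c2n1)c1cccc(Cl)c1` — compound 2 gives 68%
- compound 3, `C[C@@H](O)CCn1nc2c(Br)c(Br)c(Br)c(Br)c2n1` — compound 3 gives 71%

On these three numbers compound 1 stands lowest, that is, it shows the strongest effect of the set; compound 2 is nearest and compound 3 furthest, both beyond the scatter. Among the measured compounds shown here, the one step between compounds that differ in a single place, a number 14 percentage points higher from compound 1 to compound 2 (beyond the scatter), is modest.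

The next compound, compound 4, `CC(O)CCn1nc2c(Br)c(Br)c(Br)c(Br)c2n1`, differs from compound 1 as follows: methyl in place of 3-bromophenyl on a saturated chain carbon bound to an oxygen on a saturated carbon and a saturated chain carbon. For the measured compounds named here, no measured step covers this exchange directly; the step from compound 1 to compound 2 concerns a halogen on the ring and does not bear on the loss of the whole ring. Compound 3 carries the same methyl in the same place and differs from compound 4 only in its drawn configuration, so the values of compound 1 and compound 3 are the best guide: they point to a weaker effect after the change.

The expectation for compound 4 is therefore a step of a number 16 percentage points higher from compound 1 to compound 4 (beyond the scatter), upward, beyond the scatter. The estimated value for compound 4 is 70%, in the range 58% to 82%.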

Compound 4, a percentage reported as activity, at one concentration (the size of the read-out at that concentration, not a potency): 86%
For compound 4 the middle estimate is 16 percentage points below the measured one; the measured number lies above the stated range.
By their numbers in this assay, from the lowest: compound 1; then compounds 2 and 3 (each within the scatter of the next); then compound 4.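

In this assay, replacing the aromatic ring on this carbon with methyl now has a clear cost for both halogenated compounds: a number 32 percentage points higher from compound 1 to compound 4 (beyond the scatter) with 3-bromophenyl leaving, and a number 18 percentage points higher from compound 2 to compound 4 (beyond the scatter) with 3-chlorophenyl leaving. Methyl is also not a single fixed reference at this position, since the same atoms and bonds give a number 15 percentage points higher from compound 3 to compound 4 (beyond the scatter), so the size of any methyl exchange depends on which of the two methyl compounds is taken. That gap can be traced to only one recorded difference: the fact that one of compounds 3 and 4 is drawn with a defined configuration and the other without, at the place where they differ

Still open, as far as these compounds go, is what compound 4 holds at this stereocentre, and how the configuration at the same carbon in compound 1 and compound 2 bears on their values. Also open, from the compounds shown here alone, is how a plain phenyl, an amine or a longer chain would read at this position in this assay.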